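A few compounds are considered here, and "the series" means these few. Any claim that something is new, unique, unknown or untested is made for them only; others in the source may bear on it.

Measured compounds: compound 1 `COc1ccc([C@@H]2Cc3c(cccc3C(F)(F)F)N(C[C@@H]3CCCN3)C(=O)[C@@H]2OC(C)=O)cc1` gives 90 nM in a functional assay (aorta) with Oryctolagus cuniculus as the target; a higher number here means a weaker inhibitor, a lower number a stronger inhibitor. Compound 2 `COc1ccc([C@@H]2Sc3cc(OC)ccc3N(C[C@@H]3CCCN3)C(=O)[C@@H]2OC(C)=O)cc1` gives 120 nM. Compound 3 `COc1ccc([C@@H]2Cc3c(cccc3C(F)(F)F)N(C[C@@H]3CCCN3)C(=O)[C@@H]2O)cc1` gives 100 nM.

Compound 3 differs from compound 1 by hydrogen in place of acetyl on an oxygen on a saturated carbon. This change gave a 1.1-fold higher number from compound 1 to compound 3 (0.05 log units; within the scatter). Compound 2 carries a different core from compound 1, and the difference between the two cores is not broken down here. Its value and that of compound 3 lie within the scatter of each other.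

Compound 4 `COc1ccc([C@@H]2Sc3cc(OC)ccc3N(C[C@@H]3CCCN3)C(=O)[C@@H]2O)cc1` is related to compound 2 by hydrogen in place of acetyl on an oxygen on a saturated carbon, the same change as between compound 1 and compound 3, at the same kind of place. The expectation for compound 4 rests on compound 1 and compound 3, whose step was a 1.1-fold higher number from compound 1 to compound 3 (0.05 log units; within the scatter). Compound 4 is therefore expected to show a 1.1-fold higher number from compound 2 to compound 4 (0.03 log units; within the scatter). Compound 4 is estimated at 130 nM, with a likely range from 65 nM to 260 nM.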

Compound 4, half-maximal inhibitory concentration: 370 nM
Compound 4: middle estimate off by 2.8-fold (0.45 log units), on the low side, outside the stated range (above it).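

Replacing acetoxy with hydroxy on the core of compound 2 gave a 3.1-fold higher number from compound 2 to compound 4 (0.49 log units; beyond the scatter) in this assay, and the step did not carry over at the size seen on the core of compound 1: the same change on two cores in this assay, a 1.1-fold higher number (0.05 log units; within the scatter) from compound 1 to compound 3 and a 3.1-fold higher number (0.49 log units; beyond the scatter) from compound 2 to compound 4, 2.8-fold (0.44 log units) apart, beyond the scatter of two such steps. In these two pairs, then, the size of the step differs with the core, and the step on one core was a poor guide to the step on the other. Two pairs do not show which part of the cores lies behind this gap, nor how the change would behave on any further core.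

The compounds shown leave open whether a methyl ether or a longer acyl chain on that oxygen would track the acetyl or the hydroxy compounds. They also leave open how an amine in that place would behave on either core.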